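The source may hold more compounds than are shown below. What is called first, only, known or untested is meant among the compounds shown, and "the series" means these compounds.

Compound 1 `Cc1ccc(Nc2nc(C(F)(F)F)ccc2CNC(=O)C(C)c2ccc(NS(C)(=O)=O)c(F)c2)cc1C` was examined in a functional assay on CHO-K1 cells for antagonist activity at transient receptor potential cation channel subfamily V member 1 (Homo sapiens), read by FLIPR (on this read-out higher numbers stand for weaker inhibition and lower numbers for stronger inhibition), where compound 1 gives 39.3 nM. Of the two numbers on hand, compound 1 stands highest. Within the data shown here, the only other measured compound is compound 2 `C[C@H](C(=O)NCc1ccc(C(F)(F)F)nc1N1CCC(c2ccccc2)CC1)c1ccc(NS(C)(=O)=O)c(F)c1`, which in this assay gives 0.3 nM, a number far lower than that of compound 1 and well beyond the scatter of the method. These two compounds differ in more than one place, so nothing in the data ties their gap to a single change.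

Compound 3 `CC(C(=O)NCc1ccc(C(F)(F)F)nc1N1CCC(=O)CC1)c1ccc(NS(C)(=O)=O)c(F)c1` has not yet been measured in this assay. Relative to compound 1 it carries 4-oxopiperidin-1-yl in place of (3,4-dimethylphenyl)amino on an aromatic carbon. Among the measured compounds shown here, no measured pair shows the effect of this exchange on its own. The (3,4-dimethylphenyl)amino of compound 1 is replaced by the smaller, non-aromatic 4-oxopiperidin-1-yl, and compound 2 reaches its low number with a ring-bearing piperidine rather than a ketone-bearing one, so a modest loss rather than a gain is expected: the step of a 2.0-fold higher number from compound 1 to compound 3 (0.31 log units; beyond the scatter) is estimated to run toward weaker inhibition, of a size near the edge of the scatter. Compound 3 is therefore expected to give about 80 nM in this assay, within a range from 15 nM to 500 nM.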

Compound 3, inhibition constant: 91 nM
Estimate against measurement, compound 3: 1.1-fold (0.06 log units) below; measured number inside the range.
By their numbers in this assay, from the lowest: compound 2; then compound 1; then compound 3.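

In this assay, among these compounds, the exchange of (3,4-dimethylphenyl)amino for 4-oxopiperidin-1-yl gives the first step that can be read at this position, next to the ring nitrogen of the shared core: a 2.3-fold higher number from compound 1 to compound 3 (0.36 log units; beyond the scatter). The step is modest, and it shows that the position tolerates a change of the attached group from an aromatic ring of carbon only, carrying a hydrogen-bond donor, to a non-aromatic ring without a donor, since compound 3 still gives 91 nM. No measurement on hand explains why the number moves in this direction.

Because the ring type, the hydrogen-bond donor and the ring carbonyl all change in this single exchange, the compounds shown do not tell which of these changes accounts for the step. Also open, on these data alone, is how a plain piperidin-1-yl, a morpholin-4-yl or a 4-hydroxypiperidin-1-yl would fare at this position, and whether an unsubstituted phenylamino would differ from the (3,4-dimethylphenyl)amino of compound 1.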